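A Second Methoxy Group and Its Expected Effect

The source may hold more compounds than are shown below. What is called first, only, known or untested is meant among the compounds shown, and "the series" means these compounds.

Compound 1, `Clc1ccc(C2=NN(c3ccc(-c4ccccc4)nn3)C(c3ccc(Cl)cc3)C2)cc1`: in a functional assay on MCF7 cells (Homo sapiens) for antiproliferative activity, read by MTT assay, with a stated time of 24 h (on this read-out higher numbers stand for weaker inhibition and lower numbers for stronger inhibition), compound 1 gives 8800 nM
Compound 2, `COc1ccc(C2CC(c3ccc(Cl)cc3)=NN2c2ccc(-c3ccccc3)nn2)cc1`: in this assay compound 2 gives 100000 nM

Compound 2 stands highest of the two numbers measured in this assay; its nearest neighbour is compound 1, from which it is separated by an 11-fold higher number from compound 1 to compound 2 (1.06 log units; beyond the scatter), a change of methoxy in place of chloro on an aromatic carbon.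

Compound 3, `COc1ccc(C2CC(c3ccc(Cl)cc3)=NN2c2ccc(-c3ccccc3)nn2)c(OC)c1`, has not yet been measured. It differs from compound 2 by methoxy in place of hydrogen on an aromatic carbon, placed on an aromatic carbon of a six-membered aromatic ring of carbon only, ortho to a large group and meta to a methoxy group, so that 4-methoxyphenyl becomes 2,4-dimethoxyphenyl.

Within the data shown here, no measured step involves adding a methoxy group to an otherwise unchanged ring; the only step known, from compound 1 to compound 2, concerns a different exchange. The expectation for compound 3 in this assay is therefore a step of no change at the digits printed from compound 2 to compound 3 (within the scatter), not beyond the scatter. Compound 3 is estimated at 100000 nM, with a range from 40000 nM to 300000 nM.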

Compound 3, half-maximal inhibitory concentration: > 100000 nM
Compound 3 ended at the assay's limit (the forecaster's own chance of this, stated with the estimate: 35%); the middle value lies on the limit itself.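

In this assay compound 3 gives > 100000 nM, which is a limit of the assay and not a number. A methoxy on this carbon, ortho to a large group, gives a number no lower from compound 2 to compound 3 (the limit leaves the size open) and so did not win back what was lost when methoxy replaced chloro, but the size of this step cannot be read because the result sits at the limit: the limit of > 100000 nM in this assay, at which 1 of the 3 values shown sits.

The 2,4-dimethoxyphenyl in place of 4-chlorophenyl gives an at least 11-fold higher number from compound 1 to compound 3 (1.05 log units; beyond the scatter), so the distance from compound 1 stays beyond the scatter.

The compounds shown leave open what an amine or a hydroxyl on this same carbon would do in this assay. They also leave open how this added methoxy would read on the 4-chlorophenyl ring of compound 1, whose value is not a limit.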